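The source may hold more compounds than are shown below. What is called first, only, known or untested is meant among the compounds shown, and "the series" means these compounds.

The shared core of compound 1 `CC(C)(C)Cc1c(-c2ccc(F)cc2)sc(N)c1C(=O)c1ccc(Cl)cc1` carries a neopentyl group and a (4-chlorophenyl)carbonyl group, and in an assay on CHO cells for displacement of a labelled ligand from adenosine receptor A1 (Homo sapiens), read by scintillation counting, tested at 10 uM (on this read-out lower numbers stand for less inhibition and higher numbers for more inhibition at the one concentration tested (going by the name of the read-out)), compound 1 gives 1%. Compound 2 `CC(C)(C)Cc1c(-c2ccc(Cl)cc2)sc(N)c1C(=O)c1ccc(Cl)cc1` differs by chloro in place of fluoro on an aromatic carbon; in this assay compound 2 gives 1%. The step of no change at the digits printed from compound 1 to compound 2 (within the scatter) shows that this exchange leaves the read-out where it was, so compound 2 stands level with compound 1 at the digits shown. Both measured compounds sit near the floor of the read-out in this assay.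

Compound 3 `CC(C)(C)Cc1c(/C=C/c2ccc(Cl)cc2)sc(N)c1C(=O)c1ccc(Cl)cc1` is not yet measured. It differs from compound 2 by 2-(4-chlorophenyl)ethenyl in place of 4-chlorophenyl on an aromatic carbon. Among the compounds with values here, no measured step covers a change of this kind; the only step in hand, no change at the digits printed from compound 1 to compound 2 (within the scatter), concerns chloro in place of fluoro on an aromatic carbon and was flat. Within the data shown here, with both measured compounds near the floor in this assay and no step pointing upward, the step of a number 2 percentage points higher from compound 2 to compound 3 (within the scatter) is expected to remain within the scatter. For compound 3 the expected value in this assay is 3%, with a range from 0% to 20%.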

Compound 3, a percentage reported as inhibition, at one concentration (the size of the read-out at that concentration, not a potency): 1%
Compound 3: the middle estimate sits 2 percentage points above what was measured; low and high end bracket the measured number.
By their numbers in this assay, from the lowest: compounds 1, 2 and 3 (each within the scatter of the next).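

At the aromatic carbon next to the ring sulfur, 2-(4-chlorophenyl)ethenyl in place of 4-chlorophenyl gives no change at the digits printed from compound 2 to compound 3 (within the scatter) in this assay and, set against the fluoro analogue, 2-(4-chlorophenyl)ethenyl in place of 4-fluorophenyl gives no change at the digits printed from compound 1 to compound 3 (within the scatter) in the same read-out. The earlier pair tested only chloro in place of fluoro on the aromatic ring, whereas this change goes from 7 to 9 heavy atoms and adds 1 double bond outside aromatic rings, and the read-out still stays near its floor, so the flat result at this position now extends beyond a halogen exchange. No measurement in hand gives a reason for this flat result.

With all three compounds near the floor, these steps cannot show whether the group at this position has any bearing on the read-out, since a change that lowers it would hardly register here. Going by these compounds, what stays open is whether an amine or a carboxylic acid at this position, a longer chain in place of the neopentyl group, or an acylated form of the amino group would lift the read-out off its floor.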